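This account rests on a few compounds, and the source may have more. Where it says the series, first, only, none or still open, it means among the compounds named here.

Of the compounds shown here, two have so far been measured in a functional assay on A549 cells (Homo sapiens) for inhibition, read by colorimetric assay and MTT assay, with a stated time of 72 h; on this read-out higher numbers stand for weaker inhibition and lower numbers for stronger inhibition. Compound 1 `COc1ccc(C)cc1-c1cnc(OCCCCc2ccccc2)n1C` gives 40000 nM, and compound 2 `C=CCCCCOc1ccccc1-c1cnc(OCCCC=C)n1C` gives 3000 nM. Compound 2 thus holds the lower of the two numbers and the stronger inhibition, and the gap between them lies beyond the usual scatter. Compound 3 `C=CCCCCCOc1ncc(-c2ccccc2OCCCCC=C)n1C` has not yet been measured in this assay. It differs from compound 2 by one change, but-3-en-1-yl in place of vinyl on a saturated chain carbon, three bonds along the chain from an oxygen on an aromatic ring. Going by the values given here, no two measured compounds differ in one place only, so the data offer no direct precedent for this change, and the gap between compound 1 and compound 2 cannot be read as a guide to it. The expectation is therefore a small move towards weaker inhibition, perhaps none beyond the scatter. The estimated change is a 1.3-fold higher number from compound 2 to compound 3 (0.12 log units; within the scatter). Compound 3 is expected to give 4000 nM, with an estimated range of 1200 nM to 15000 nM.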

Compound 3, half-maximal inhibitory concentration: 62000 nM
Estimate against measurement, compound 3: 16-fold (1.19 log units) below; the whole stated range lies below it.
By their numbers in this assay, from the lowest: compound 2; then compounds 1 and 3 (each within the scatter of the next).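

In this assay, the change of but-3-en-1-yl in place of vinyl, on a saturated chain carbon, three bonds along the chain from an oxygen on an aromatic ring, gives a 21-fold higher number from compound 2 to compound 3 (1.32 log units; beyond the scatter), a large move towards weaker inhibition. Read one bond further out, this is pent-4-en-1-yl to hept-6-en-1-yl, so this position is not indifferent to the chain it carries, which the earlier pair of compounds, differing in more than one place, could not show. The group that enters adds two carbons while the count of double bonds stays the same, with no ring, hydrogen-bond donor, hydrogen-bond acceptor or net charge on either side, and nothing available explains why this change goes with the loss of inhibition.

On these data alone, this single step gives no view of how the response runs across chain lengths, so it remains open whether a shorter allyl chain or an intermediate hex-5-en-1-yl chain would stay near compound 2. It also leaves open whether the end of the chain matters, as a saturated hexyl chain, an amine or a carboxylic acid there could show.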